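From an allyl to a dichlorobenzyl group on sulfur

The source may hold more compounds than are shown below. What is called first, only, known or untested is meant among the compounds shown, and "the series" means these compounds.

- compound 1 `Cc1cc(N2CC[C@@H](C)[C@@H](N(C)c3ncnc4[nH]ccc34)C2)n2nc(SCc3nc4ccccc4[nH]3)nc2n1` gives 21200 nM
- compound 2 `Cc1cc(N2CC[C@@H](C)[C@@H](N(C)c3ncnc4[nH]ccc34)C2)n2nc(SCC3CCCCC3)nc2n1` gives 9170 nM
- compound 3 `C=CCSc1nc2nc(C)cc(N3CC[C@@H](C)[C@@H](N(C)c4ncnc5[nH]ccc45)C3)n2n1` gives 32600 nM

These values come from a functional assay on MGC-803 cells (Homo sapiens) for inhibition, read by MTT assay, with a stated time of 72 h (on this read-out lower numbers stand for stronger inhibition and higher numbers for weaker inhibition), and place compound 3 at the high end of the set together with compound 1, the two lying within the scatter of each other. Compound 4 `Cc1cc(N2CC[C@@H](C)[C@@H](N(C)c3ncnc4[nH]ccc34)C2)n2nc(SCc3cc(Cl)ccc3Cl)nc2n1` has 2,5-dichlorophenyl in place of vinyl on a saturated chain carbon bound to a sulfur so allyl becomes 2,5-dichlorobenzyl. Two measured swaps at this place bear on the change. Vinyl in place of cyclohexyl gave a 3.6-fold higher number from compound 2 to compound 3 (0.55 log units; beyond the scatter) while vinyl in place of 1H-benzimidazol-2-yl gave a 1.5-fold higher number from compound 1 to compound 3 (0.19 log units; within the scatter) and so goes against any rule that a ring here always lowers the number. Among the compounds with values here, no measured compound carries a chlorinated ring. In this assay a modest step towards a lower number is therefore expected, with real uncertainty. The estimate amounts to a 2.5-fold lower number from compound 3 to compound 4 (0.40 log units; beyond the scatter) as the expected step. The estimate for compound 4 is 13000 nM with 4500 nM to 35000 nM as the expected range.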

Compound 4, half-maximal inhibitory concentration: 9850 nM
Estimate against measurement, compound 4: 1.3-fold (0.12 log units) above; measured number inside the range.
By their numbers in this assay, from the lowest: compounds 2 and 4 (each within the scatter of the next); then compounds 1 and 3 (each within the scatter of the next).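

In this assay, the 2,5-dichlorobenzyl group on sulfur clearly lowers the number compared with allyl (a 3.3-fold lower number from compound 3 to compound 4 (0.52 log units; beyond the scatter)). It does the same compared with the benzimidazole-bearing group of compound 1 (a 2.2-fold lower number from compound 1 to compound 4 (0.33 log units; beyond the scatter)), so an aromatic ring at this place does not by itself decide the result, as compound 1 also carries one. Against the cyclohexyl group of compound 2, the step is within the scatter (a 1.1-fold higher number from compound 2 to compound 4 (0.03 log units; within the scatter)), so the chlorinated aromatic ring and the saturated ring cannot be told apart here.

No measurement at hand explains why these groups rank as they do. Also open, as far as these compounds go, is how this position would respond to a ring with a single chlorine, to an amine or carboxylic acid on the ring, or to a longer chain between the sulfur and the ring.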